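The compounds below may be only part of what the source reports. "The series", "measured", "known", "first", "only" and "open" are said of these compounds alone.

Measured so far:
compound 1 `N#Cc1cccc(S(=O)(=O)c2cnc3c(F)cccc3c2-c2cccc(Cl)c2)c1` — 1.11 mL/min
compound 2 `O=S(=O)(c1cccc(F)c1)c1cnc2c(F)cccc2c1-c1ccc(F)cc1` — 0.19 mL/min

Within this pair compound 2 holds the lowest number in an ADME assay on microsomes from liver (Homo sapiens) for metabolic stability, tested at 2.5 uM; on this read-out lower numbers stand for slow clearance and higher numbers for fast clearance; the nearest, compound 1, gives 1.11 mL/min, a gap that lies beyond the usual scatter of the measurement. Compound 3 `N#Cc1cccc(S(=O)(=O)c2cnc3c(F)cccc3c2-c2ccc(F)cc2)c1` is not yet measured. It differs from compound 2 by cyano in place of fluoro on an aromatic carbon, placed on an aromatic carbon of a six-membered aromatic ring of carbon only, meta to a large group; cut one bond further out, the change reads 3-fluorophenyl to 3-cyanophenyl. Compound 1 also carries the 3-cyanophenyl, but its other aryl group is not the same, so its value can only bracket what the change may bring. Going by the values given here, no step between measured compounds isolates this change. In this assay the step is expected to run upward, from the low number of compound 2 toward that of compound 1, by an amount somewhat beyond the scatter rather than the full gap. Compound 3 is therefore estimated at 0.45 mL/min, within 0.2 mL/min to 1.1 mL/min. The step this estimate implies is a 2.4-fold higher number from compound 2 to compound 3 (0.37 log units; beyond the scatter), an expectation, not a measurement.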

Compound 3, intrinsic clearance in a liver preparation (reported as CLH), per the amount of preparation that the assay uses: 0.19 mL/min
For compound 3 the middle estimate is 2.4-fold (0.37 log units) above the measured one; the measured number lies below the stated range.
By their numbers in this assay, from the lowest: compounds 2 and 3 (each within the scatter of the next); then compound 1.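

At this position, on an aromatic carbon of a six-membered aromatic ring of carbon only and meta to a large group, cyano in place of fluoro is tolerated with the 4-fluorophenyl present: this assay shows no change at the digits printed from compound 2 to compound 3 (within the scatter). With the 3-cyanophenyl held constant, the other aryl group is where the series moves, with 4-fluorophenyl in place of 3-chlorophenyl giving a 5.8-fold lower number from compound 1 to compound 3 (0.77 log units; beyond the scatter), so the nitrile itself does not accompany a high number in this pair. No supporting measurement accounts for either step.

It remains open whether the swap from 3-fluorophenyl to 3-cyanophenyl would be just as silent with 3-chlorophenyl as the other aryl group, since the compounds shown test it only with 4-fluorophenyl. Also open, from the compounds shown here alone, is how far this position tolerates groups beyond fluoro and cyano, such as a primary amide, a carboxylic acid or an aminomethyl, and whether other halogens on the second aryl group follow 4-fluorophenyl or 3-chlorophenyl.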